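Azido to Amino on the Side Chain: Expected Maximal Response

The compounds below may be only part of what the source reports. "The series", "measured", "known", "first", "only" and "open" are said of these compounds alone.

Of the compounds shown here, two sharing one core have been measured in a functional assay on the whole organism (B cells) with Mus musculus as the target; a lower number here means a smaller maximal response, a higher number a larger maximal response. Compound 1 `[N-]=[N+]=NCC(O)Cn1c(=O)n(C2OC(CO)[C@@H](O)[C@H]2O)c2nc(N)nc(O)c21` carries a 3-azido-2-hydroxypropyl group on that core, and in this assay compound 1 gives 91%. Compound 2 `C=CCn1c(=O)n([C@@H]2O[C@H](CO)[C@H]3OC(CCC)(CCC)O[C@H]32)c2nc(N)nc(O)c21`, the other measured member, gives 123% in this assay. Going by the values given here, compound 1 thus stands at the lowest of the two numbers known so far, with compound 2 the nearer and only neighbour, and the gap between them lies beyond the usual scatter of this kind of measurement.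

Compound 3 `NCC(O)Cn1c(=O)n(C2OC(CO)[C@@H](O)[C@H]2O)c2nc(N)nc(O)c21` has not yet been measured. It differs from compound 1 in a single respect: amino in place of azido on a saturated chain carbon, two bonds along the chain from an oxygen on a saturated carbon. Among the compounds with values here, no pair of measured compounds shows this same change, so nothing in the present numbers fixes its size or direction. The account therefore rests on compound 1 alone, and the step of a number 1 percentage points lower from compound 1 to compound 3 (within the scatter) is expected to stay small, with no clear direction beyond the scatter. Compound 3 is expected to reach about 90% in this assay, within a range from 60% to 125%.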

Compound 3, largest response reached (reported as maximal response), in percent of the reference or control that the assay uses: 110%
Compound 3: the middle estimate sits 20 percentage points below what was measured, and the stated range covers the measured number.
By their numbers in this assay, from the lowest: compound 1; then compound 3; then compound 2.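

In this assay, the change from 3-azido-2-hydroxypropyl to 3-amino-2-hydroxypropyl now has a measured size and direction: amino in place of azido on a saturated chain carbon, two bonds along the chain from an oxygen on a saturated carbon, gives a number 19 percentage points higher from compound 1 to compound 3 (beyond the scatter), a modest step. Going by these compounds alone, until this pair, no measured step had isolated a change at this place, so it is the first sign that the maximal response is sensitive to what the end of this side chain carries, with the rest of the molecule held the same. Nothing available accounts for the step, so the numbers record only that it occurs.

On these data alone, what remains open is whether this rise belongs to the amino group specifically or would also appear with other replacements for azido, since a single step at a single place cannot separate the two. A dimethylamino group, an acetamide or a carboxylic acid at the same carbon, or a longer chain carrying the amino group, would show how far the step extends.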